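The source may report more compounds than this note shows. Statements on the series, on what has been measured and on what is new or still open speak of the compounds shown alone.

Among the compounds with values here, compound 2, `Cc1ccc(S(=O)(=O)c2nc3ccccc3nc2N2CCCC(O)C2)cc1`, gives 5330 nM in a functional assay on PC-3 cells (Homo sapiens) for cytotoxicity, read by MTT assay, with a stated time of 72 h (on this read-out lower numbers stand for stronger inhibition and higher numbers for weaker inhibition), the only actual number among the two compounds measured so far. Compound 1, `Cc1ccc(S(=O)(=O)c2nc3ccccc3nc2N2CCCC2)cc1`, reaches only the limit of > 50000 nM in this assay. Within the data shown here, the single measured step, an at least 9.3-fold lower number from compound 1 to compound 2 (0.97 log units; beyond the scatter), turns a limit into a number, as recorded in the limit of > 50000 nM in this assay, at which 1 of the 2 values shown sits. Compound 3, `O=S(=O)(c1ccc(F)cc1)c1nc2ccccc2nc1N1CCCC(O)C1`, differs from compound 2 by fluoro in place of methyl on an aromatic carbon. No measured step touches that part of the molecule: the one step recorded alters the saturated ring attached to the shared core, not the aryl group of the sulfone, so nothing shown speaks directly to the size or direction of this change. One therefore expects no step beyond the scatter for a 1.1-fold higher number from compound 2 to compound 3 (0.05 log units; within the scatter). The estimate for compound 3 is accordingly placed at 6000 nM, within a range from 2000 nM to 20000 nM.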

Compound 3, half-maximal inhibitory concentration: 2130 nM
Compound 3: the middle estimate sits 2.8-fold (0.45 log units) above what was measured, within the range that was stated.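

In this assay, the change from 4-methylphenyl to 4-fluorophenyl gives a 2.5-fold lower number from compound 2 to compound 3 (0.40 log units; beyond the scatter), a modest step but one beyond the scatter. Within the data shown here, the earlier step concerned only the saturated ring on the shared core, so this is the first measured sign that the number also responds to the group at this place on the aryl ring of the sulfone, and that methyl is not needed there to keep the activity seen with compound 2. No measurement shown gives a reason for this step.

On these data alone, whether chloro, methoxy or trifluoromethyl at the same place would lower the number further remains open. As far as these compounds go, it is also open whether the fluoro for methyl change would give a step of like size with pyrrolidin-1-yl in place of 3-hydroxypiperidin-1-yl on the shared core.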